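The source may report more compounds than this note shows. Statements on the series, on what has been measured and on what is new or still open speak of the compounds shown alone.

In a functional assay on HCT-15 cells (Homo sapiens) for cytotoxicity, read by colorimetric assay and MTT assay (a lower number here means a stronger inhibitor, a higher number a weaker inhibitor), three compounds have been measured so far:
compound 1 `CCOC(=O)Cn1c(=O)c(-c2ccc(OC)cc2)cc2c(OC)cc(OC)cc21` gives 10000 nM
compound 2 `COc1ccc(-c2cc3c(OC)cc(OC)cc3n(CC#N)c2=O)cc1` gives 10000 nM
compound 3 `COc1ccc(-c2cc3c(OC)cc(OC)cc3n(CC(=O)OCc3ccccc3)c2=O)cc1` gives 10000 nM

Compound 3 stands level with compound 1 and compound 2, with nothing separating the three on these numbers. Compound 4 `COc1ccc(-c2cc3c(OC)cc(OC)cc3n(CC(=O)O)c2=O)cc1` carries hydrogen in place of benzyl on an oxygen next to a carbonyl group, so benzyloxycarbonyl becomes carboxy, and the full difference is hydrogen in place of benzyl on an oxygen next to a carbonyl group in all. Within the data shown here, three measured steps bear on this: no change at the digits printed from compound 1 to compound 3 (within the scatter), no change at the digits printed from compound 2 to compound 3 (within the scatter) and no change at the digits printed from compound 1 to compound 2 (within the scatter) are the whole of the evidence. Among the measured compounds shown here, none of the measured compounds carries a carboxy group, so that evidence is indirect. A step beyond the scatter is therefore not expected in this assay in either direction. The expected step is no change at the digits printed from compound 3 to compound 4 (within the scatter) on this reading. For compound 4 the estimated value is 10000 nM with an expected range from 5000 nM to 20000 nM as its upper end.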

Compound 4, half-maximal inhibitory concentration: 10000 nM
The estimate for compound 4 equals the measured number at the digits printed, within the range that was stated.
By their numbers in this assay, from the lowest: compounds 1, 2, 3 and 4 (each within the scatter of the next).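

With the carboxy group in place, this assay still separates nothing at this position: there is no change at the digits printed from compound 3 to compound 4 (within the scatter), no change at the digits printed from compound 1 to compound 4 (within the scatter) and no change at the digits printed from compound 2 to compound 4 (within the scatter). So hydrogen in place of benzyl or ethyl on the oxygen next to a carbonyl group leaves the reading where the esters and the nitrile stand. No measurement shown here accounts for this flat result.

From the compounds shown here alone, whether an amine, an amide or a longer chain in place of carboxymethyl would move the reading away from that of compound 4 at 10000 nM stays open.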